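Shifting two methyl groups around a cyclohexenone ring

This account rests on a few compounds, and the source may have more. Where it says the series, first, only, none or still open, it means among the compounds named here.

Compound 3 `C[C@@H](O[C@@H]1CN(C2=CC(=O)C(C)(C)CC2)C[C@H]1c1ccccc1)c1cc(C(F)(F)F)cc(C(F)(F)F)c1` gives 0.18 nM in an assay on CHO cells for displacement of a labelled ligand from Substance-P receptor (Homo sapiens); on this read-out lower numbers stand for stronger inhibition and higher numbers for weaker inhibition. Its number is level with compound 1 `C[C@@H](O[C@@H]1CN(C(=O)C(C)(C)C)C[C@H]1c1ccccc1)c1cc(C(F)(F)F)cc(C(F)(F)F)c1` at 0.18 nM, and close to compound 2 `C[C@@H](O[C@@H]1CN(C(=O)N2CCOCC2)C[C@H]1c1ccccc1)c1cc(C(F)(F)F)cc(C(F)(F)F)c1` at 0.16 nM; all three sit within the scatter of one another. Compound 4 `C[C@@H](O[C@@H]1CN(C2=CC(=O)CC(C)(C)C2)C[C@H]1c1ccccc1)c1cc(C(F)(F)F)cc(C(F)(F)F)c1` differs from compound 3 only by 5,5-dimethyl-3-oxocyclohex-1-en-1-yl in place of 4,4-dimethyl-3-oxocyclohex-1-en-1-yl on an amine nitrogen in a ring. The measured steps that touch this ring, no change at the digits printed from compound 1 to compound 3 (within the scatter) and a 1.1-fold higher number from compound 2 to compound 3 (0.05 log units; within the scatter), show that swapping very different groups at this nitrogen left the number unchanged, so a small rearrangement within the same ring is expected to matter even less. For compound 4 the expected step is a 1.1-fold higher number from compound 3 to compound 4 (0.05 log units; within the scatter), none beyond the scatter. Compound 4 is therefore estimated at 0.2 nM, within 0.1 nM to 0.5 nM.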

Compound 4, half-maximal inhibitory concentration: 0.13 nM
Compound 4: middle estimate off by 1.5-fold (0.19 log units), on the high side; the measured number falls inside the stated range.
By their numbers in this assay, from the lowest: compounds 4, 2, 1 and 3 (each within the scatter of the next).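

In this assay, moving the two methyl groups around the ring gives a 1.4-fold lower number from compound 3 to compound 4 (0.14 log units; within the scatter), so the new isomer fits this nitrogen as well as the old one. Against the two carbonyl-linked groups the picture is the same, with a 1.2-fold lower number from compound 2 to compound 4 (0.09 log units; within the scatter) and a 1.4-fold lower number from compound 1 to compound 4 (0.14 log units; within the scatter), leaving all four groups at this nitrogen level within the scatter. No measurement at hand explains this flat result. Still open, going by these compounds, is whether a carboxylic acid or a longer chain on the cyclohexenone ring would leave the number equally undisturbed.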